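Pyridyl to imidazolyl swap on the propyl chain

The compounds below may be only part of what the source reports. "The series", "measured", "known", "first", "only" and "open" are said of these compounds alone.

Within the data shown here, compound 2 `N/C(=N\C(=O)CC(c1ccccc1)c1ccccc1)NCCCc1cccnc1` gives 6.14 in a functional assay on Sf9 cells for antagonist activity at histamine H2 receptor (Homo sapiens), with stated times of 2 min and 20 min (a higher number here means a more potent compound, by a factor of ten per unit of this negative logarithm, a lower number a less potent compound), the highest number among the three measured so far. Compound 3 `CN(C)Cc1ccc(CCCN/C(N)=N/C(=O)CC(c2ccccc2)c2nccs2)o1` gives 6.13, which lies within the scatter of compound 2. Compound 1 `CC(CC(=O)/N=C(\N)NCCCc1cccnc1)c1ccccc1` gives 5.27; the step from compound 1 to compound 2 is a number 0.87 log units higher from compound 1 to compound 2 (beyond the scatter), and it lies beyond the scatter. That step concerns the carbon bearing the phenyl groups, not the chain end.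

Compound 4 `N/C(=N\C(=O)CC(c1ccccc1)c1ccccc1)NCCCc1ncc[nH]1` differs from compound 2 in 1H-imidazol-2-yl in place of pyridin-3-yl on a saturated chain carbon, three bonds along the chain from an amine nitrogen. No measured step touches this part of the molecule, so nothing shown bears directly on the change; the one step recorded, a number 0.87 log units higher from compound 1 to compound 2 (beyond the scatter), is at another place and gives no guidance on the ring at the chain end. The change is therefore expected to lie within the scatter in this assay, in either direction, and the expected step from compound 2 to compound 4 is a number 0.04 log units lower from compound 2 to compound 4 (within the scatter). Compound 4 is estimated at 6.1, with a range from 5.4 to 6.8.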

Compound 4, negative logarithm of the antagonist equilibrium constant: 6.13
Compound 4: the middle estimate sits 0.03 log units below what was measured; the range from low to high includes it.
By their numbers in this assay, from the lowest: compound 1; then compounds 3, 4 and 2 (each within the scatter of the next).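

Working notes on the ring at the chain end: in this assay, the first step read at this position is a number 0.01 log units lower from compound 2 to compound 4 (within the scatter), so with the rest of compound 2 kept, the two rings cannot be told apart by this read-out. The 3-(pyridin-3-yl)propyl group can therefore give way to 3-(1H-imidazol-2-yl)propyl, a change from a six-membered to a five-membered aromatic ring that adds a hydrogen-bond donor, without a step beyond the scatter. Nothing available explains why the two rings read alike.

From the compounds shown here alone, whether this holds with the methyl and phenyl pair of compound 1 on the saturated chain carbon remains open, as a single pair cannot show it. Also open, going by these compounds, is how a butyl chain carrying either ring, or a carboxylic acid at the chain end, would read in this assay here.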